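Removing the methoxy group from compound 1

This account rests on a few compounds, and the source may have more. Where it says the series, first, only, none or still open, it means among the compounds named here.

The measured compounds:
compound 1 `COc1ccc(-c2[nH]c3ccccc3c2/C=C(\C#N)S(=O)(=O)c2ccccc2)cc1` gives 374 nM
compound 2 `COc1ccc2[nH]c(-c3ccccc3)c(C=C(C#N)C#N)c2c1` gives 3500 nM
compound 3 `COc1ccc(-c2[nH]c3ccc(OC)cc3c2C=C(C#N)C#N)cc1` gives 590 nM

In a functional assay on KM12 cells (Homo sapiens) for inhibition, read by sulforhodamine B assay, with a stated time of 48 h (on this read-out higher numbers stand for weaker inhibition of growth and lower numbers for stronger inhibition of growth), compound 1 gives the lowest of the three numbers. Its nearest neighbour is compound 3, whose number is within the scatter of that of compound 1, while the number for compound 2 lies beyond the scatter above it. Compound 4 `N#C/C(=C\c1c(-c2ccccc2)[nH]c2ccccc12)S(=O)(=O)c1ccccc1` differs from compound 1 in one place: hydrogen in place of methoxy on an aromatic carbon, which read one bond further out is 4-methoxyphenyl to phenyl.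

Within the data shown here, one measured step bears on this change. Going from compound 2 to compound 3, a methoxy group enters at an aromatic carbon of the same kind of ring, and the number drops: a 5.9-fold lower number from compound 2 to compound 3 (0.77 log units; beyond the scatter). The change from compound 1 to compound 4 runs in the opposite direction, so the number is expected to rise. Because the step of a 5.9-fold lower number from compound 2 to compound 3 (0.77 log units; beyond the scatter) was modest, the rise from compound 1 to compound 4 is expected to be of similar size, a 4.0-fold higher number from compound 1 to compound 4 (0.60 log units; beyond the scatter). Compound 4 is therefore expected to give about 1500 nM, in a range from 500 nM to 5000 nM, in this assay.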

Compound 4, concentration for 50% growth inhibition: 652 nM
Beside the measured number, compound 4's estimate is 2.3-fold (0.36 log units) above it; measured number inside the range.
By their numbers in this assay, from the lowest: compounds 1, 3 and 4 (each within the scatter of the next); then compound 2.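

In this assay, the change from 4-methoxyphenyl to phenyl on the core of compound 1 reads as a 1.7-fold higher number from compound 1 to compound 4 (0.24 log units; within the scatter), so on this core the methoxy group cannot be told apart from hydrogen at this place. The earlier compounds shown here showed this change only on the core of compound 2, where it was beyond the scatter, and that step does not carry over to the core of compound 1. The size of the step therefore differs with the core that carries it, and the gap between the two cores is itself larger than the scatter allows: the same change on two cores in this assay, a 5.9-fold lower number (0.77 log units; beyond the scatter) from compound 2 to compound 3 and a 1.7-fold lower number (0.24 log units; within the scatter) from compound 4 to compound 1, 3.4-fold (0.53 log units) apart, beyond the scatter of two such steps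

As far as these compounds go, whether another group at this place, such as an amine, a fluorine atom or a longer alkoxy chain, would move the number beyond the scatter on either core remains open. From the compounds shown here alone, it is also open which structural difference sets the gap between the two steps, the methoxy group on the core of compound 2 or the sulfonyl group carried by compound 1 and compound 4.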